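Swapping Bromo for Cyano on a Shared Quinoline Core

The source may hold more compounds than are shown below. What is called first, only, known or untested is meant among the compounds shown, and "the series" means these compounds.

Measured compounds:
Compound 1, `COc1cc([C@](O)(CCN(C)C)[C@@H](c2cc3cc(Br)ccc3nc2OC)c2ccnc(OC)c2OC)cc(OC(F)F)n1`, gives 2.1 uL/min.
Compound 2, `COc1cc([C@](O)(CCN(C)C)[C@@H](c2cc3cc(C#N)ccc3nc2OC)c2ccnc(OC)c2OC)cc(OC(F)F)n1`, gives 2.5 uL/min.
Compound 3, `COc1cc([C@](O)(CCN(C)C)[C@@H](c2cc3cc(Br)ccc3nc2OC)c2cccc(OC)c2F)cc(SC)n1`, gives 4.8 uL/min.

These three values come from an ADME assay on microsomes from liver (Homo sapiens) for metabolic stability; on this read-out higher numbers stand for fast clearance and lower numbers for slow clearance. Compound 1 and compound 2 share one core and differ in a single place: cyano in place of bromo on an aromatic carbon. That change produced a 1.2-fold higher number from compound 1 to compound 2 (0.08 log units; within the scatter), so the two numbers cannot be told apart by this read-out. Compound 3 carries a different core; the difference between the two cores is not broken down here. Its value in this assay stands above that of compound 1 by a step beyond the scatter, while against compound 2 the gap is within the scatter.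

Compound 4, `COc1cc([C@](O)(CCN(C)C)[C@@H](c2cc3cc(C#N)ccc3nc2OC)c2cccc(OC)c2F)cc(SC)n1`, has not yet been measured in this assay. It differs from compound 3 in exactly the same way that compound 2 differs from compound 1: cyano in place of bromo on an aromatic carbon. The place lines of the two changes agree word for word, so this is the same change on a new core.

Among the measured compounds shown here, with only one earlier example of this change to lean on, the expectation for compound 4 rests on that one step: because a 1.2-fold higher number from compound 1 to compound 2 (0.08 log units; within the scatter) stayed within the scatter, the step from compound 3 to compound 4 is expected to be small as well, around a 1.1-fold higher number from compound 3 to compound 4 (0.06 log units; within the scatter). Compound 4 is therefore estimated at 5.5 uL/min, most likely between 2.5 uL/min and 12 uL/min.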

Compound 4, intrinsic clearance in a liver preparation (reported as CLH), per the amount of preparation that the assay uses: 16 uL/min
Compound 4: the middle estimate sits 2.9-fold (0.46 log units) below what was measured, and the stated range ends below it.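

On the second core, cyano in place of bromo on an aromatic carbon gave a 3.3-fold higher number from compound 3 to compound 4 (0.52 log units; beyond the scatter) in this assay. Set beside the earlier step, the same swap did not read the same on the two cores: the same change on two cores in this assay, a 1.2-fold higher number (0.08 log units; within the scatter) from compound 1 to compound 2 and a 3.3-fold higher number (0.52 log units; beyond the scatter) from compound 3 to compound 4, 2.8-fold (0.45 log units) apart, beyond the scatter of two such steps

This shows that, for this pair of cores, a step measured on one core was not a reliable guide to the step on the other, even though the group that leaves, the group that enters and the place described are the same; it does not show which of the several differences between the two cores goes with the larger step, why the number rose, or whether the swap would behave in either of these ways on any further core.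

The compounds shown leave open how chloro, methyl or trifluoromethyl on that same aromatic carbon would read on either core, and whether any of them would stay as close to bromo as cyano does on the first core. They also leave open which part of the second core matters, something that pairs of compounds differing in only one of those places could begin to settle.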